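Working notes: compound 4, the vinyl analogue, in cytotoxicity

The source may report more compounds than this note shows. Statements on the series, on what has been measured and on what is new or still open speak of the compounds shown alone.

Measured so far:
compound 1 `C[C@H]1[C@H](NCc2cc(C3CC3)cs2)C[C@H]2C[C@@H]1C2(C)C`: 25000 nM
compound 2 `CCc1ccc(CN[C@@H]2C[C@H]3C[C@@H]([C@H]2C)C3(C)C)s1`: 1560 nM
compound 3 `C=C(C)c1csc(CN[C@@H]2C[C@H]3C[C@@H]([C@H]2C)C3(C)C)c1`: 25000 nM

In an ADME assay on MDCK cells (Canis lupus familiaris) for cytotoxicity, read by microscopy, with a stated time of 48 h (a lower number here means that less compound is tolerated, a higher number that more compound is tolerated), compound 3 gives 25000 nM, level with compound 1 at 25000 nM within the scatter, and together the highest of the three numbers. Compound 2 at 1560 nM stands furthest from compound 3, a gap beyond the scatter.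

Compound 4 `C=Cc1csc(CN[C@@H]2C[C@H]3C[C@@H]([C@H]2C)C3(C)C)c1` differs from compound 3 by hydrogen in place of methyl on a double-bonded chain carbon bound to an aromatic carbon. Among the compounds with values here, the one measured step that bears on it, no change at the digits printed from compound 1 to compound 3 (within the scatter), swapped a group on the same aromatic carbon and left this assay unchanged within the scatter. Trimming one carbon from that group is a smaller change still, so no step beyond the scatter is expected; the estimated step is no change at the digits printed from compound 3 to compound 4 (within the scatter). Compound 4 is therefore expected at 25000 nM, in the range 12500 nM to 50000 nM.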

Compound 4, minimum cytotoxic concentration: 6250 nM
Estimate against measurement, compound 4: 4.0-fold (0.60 log units) above; the measured number lies below the stated range.
By their numbers in this assay, from the lowest: compound 2; then compound 4; then compounds 1 and 3 (each within the scatter of the next).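

In this assay, the group on this aromatic carbon does move the number: a 4.0-fold lower number from compound 3 to compound 4 (0.60 log units; beyond the scatter), and a 4.0-fold lower number from compound 1 to compound 4 (0.60 log units; beyond the scatter), whereas no change at the digits printed from compound 1 to compound 3 (within the scatter). Losing one methyl from the double-bonded chain is therefore enough for a step beyond the scatter, and vinyl stands apart here from both 1-methylethenyl and cyclopropyl. As far as these compounds go, whether an amine or a methoxy group on this aromatic carbon would follow vinyl or the other two groups remains open. No available data explain the step from 1-methylethenyl to vinyl.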